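Fluoro added to the benzyl ring of a coumarin series

The compounds below may be only part of what the source reports. "The series", "measured", "known", "first", "only" and "open" are said of these compounds alone.

In an ADME assay on isolated protein for inhibition of Amine oxidase [flavin-containing] A (Homo sapiens), read by fluorescence and Amplex Red, with stated times of 15 min and 20 min (a lower number here means a stronger inhibitor, a higher number a weaker inhibitor), compound 1 `C#CCN(CCCOc1ccc2ccc(=O)oc2c1)Cc1ccc(OC)cc1` gives 60000 nM, compound 2 `C#CCN(CCCCOc1ccc2ccc(=O)oc2c1)Cc1cccc(F)c1` gives 69200 nM and compound 3 `C#CCN(C)CCCOc1ccc2ccc(=O)oc2c1` gives 36900 nM. Compound 2 carries the top number of the three, yet its gaps to compound 1 and to compound 3 both lie within the scatter. Compound 4 `C#CCN(CCCCOc1ccc2ccc(=O)oc2c1)Cc1ccc(F)c(F)c1` differs from compound 2 by fluoro in place of hydrogen on an aromatic carbon. Among the measured compounds shown here, the only measured step, a 1.6-fold lower number from compound 1 to compound 3 (0.21 log units; within the scatter), concerns the group on the amine nitrogen, not the aromatic ring, and was itself within the scatter, so it bears only loosely on this change. No step beyond the scatter is therefore expected in this assay. Compound 4 is estimated at 60000 nM, with a range from 25000 nM to 150000 nM, which means an expected step of a 1.2-fold lower number from compound 2 to compound 4 (0.06 log units; within the scatter).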

Compound 4, half-maximal inhibitory concentration: 93200 nM
Estimate against measurement, compound 4: 1.6-fold (0.19 log units) below, and the stated range covers the measured number.
By their numbers in this assay, from the lowest: compounds 3, 1, 2 and 4 (each within the scatter of the next, the first and the last beyond it).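

The change from 3-fluorobenzyl to 3,4-difluorobenzyl gives a 1.3-fold higher number from compound 2 to compound 4 (0.13 log units; within the scatter) in this assay, the first reading shown for a change on this aromatic ring. Fluoro on this carbon, ortho to a fluoro group and para to a large group, therefore does not separate compound 4 from compound 2 in this assay. The earlier step concerned only the group on the amine nitrogen.

As far as these compounds go, whether chloro, methoxy or an amine on this carbon would give a step beyond the scatter stays open. No measurement shown offers an explanation for this result.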